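The compounds below may be only part of what the source reports. "The series", "measured", "known", "first", "only" and "open" are said of these compounds alone.

Going by the values given here, in a functional assay on the whole organism with Mus musculus as the target, in the maximal electroshock model (on this read-out higher numbers stand for an effect only at larger amounts of compound and lower numbers for an effect already at smaller amounts), compound 1 (`CC1CCSC1=O`) gives 91 mg/kg and compound 2 (`CC1(C)CCSC1=O`) gives 369 mg/kg as the higher of the two numbers measured so far. Compound 3 (`CC(C)C1(C)CCSC1=O`) changes one group of compound 2 (isopropyl in place of methyl on a saturated ring carbon), with isopropyl in place of methyl on a saturated ring carbon. Among the compounds with values here, only one measured step bears on this change: a 4.1-fold higher number from compound 1 to compound 2 (0.61 log units; beyond the scatter) came with methyl in place of hydrogen on a saturated ring carbon, a modest move beyond the scatter. That single step is a thin guide. It shows what followed when a hydrogen gave way to a methyl, but the data hold no case of a methyl giving way to a larger group. One step also makes no trend, so its upward direction cannot simply be carried forward. The expected result in this assay is therefore no step beyond the scatter, and the estimate amounts to a 1.2-fold lower number from compound 2 to compound 3 (0.09 log units; within the scatter) at the middle of a wide range. For compound 3 the expected value is 300 mg/kg (estimated range 100 mg/kg to 800 mg/kg).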

Compound 3, dose for half-maximal effect: > 500 mg/kg
Compound 3 gave a limit, no number; the forecaster's own chance of this, stated with the estimate: 10%; at least 1.6-fold (0.22 log units) between middle value and limit.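

In this assay compound 3 gives no number but a limit: the limit of > 500 mg/kg in this assay, at which 1 of the 3 values shown sits.

Even so, this adds something that the earlier compounds could not show, namely what happens when a group larger than methyl sits on the saturated ring carbon two ring bonds from the ring sulfur. Going from methyl to isopropyl gives an at least 1.3-fold higher number from compound 2 to compound 3 (0.13 log units; that floor lies within the scatter), so this change is not shown to go beyond the scatter, although a limit leaves room for a larger step. Measured against the hydrogen of compound 1, isopropyl gives an at least 5.4-fold higher number from compound 1 to compound 3 (0.73 log units; beyond the scatter), so both groups that replace this hydrogen, methyl in compound 2 and isopropyl in compound 3, go with effect only at larger amounts of compound.

On these data alone, the true size of the step from methyl to isopropyl stays open, so these two groups cannot be put in order on this carbon. Also open, as far as these compounds go, is whether a group of a different kind in the same place, such as an amine, a hydroxyl or a phenyl ring, or a longer chain such as butyl, would follow the same direction.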